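A few compounds are considered here, and "the series" means these few. Any claim that something is new, unique, unknown or untested is made for them only; others in the source may bear on it.

Measured so far in a functional assay on A549 cells (Homo sapiens) for antiproliferative activity, read by MTT assay, with a stated time of 96 h; a higher number here means a weaker inhibitor, a lower number a stronger inhibitor:
- compound 1 `S=C(N/N=C1\CC2(CCCCC2)Oc2c1ccc1ccccc21)N1CCCCC1`: 11400 nM
- compound 2 `Cc1ccc(NC(=O)N/N=C2\CC3(CCCCC3)Oc3c2ccc2ccccc32)cc1`: 8350 nM

Compound 1 holds the highest of the two numbers; its nearest neighbour is compound 2, and the step of a 1.4-fold lower number from compound 1 to compound 2 (0.14 log units; within the scatter) stays within the scatter, so the two cannot be ranked against each other on these data.

Compound 3 `N/N=C1\CC2(CCCCC2)Oc2c1ccc1ccccc21` has not yet been run in this assay. It differs from compound 1 as follows: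
a hydrogen atom in place of a group of 8 heavy atoms (6 carbon, 1 nitrogen, 1 sulfur; one six-membered non-aromatic ring with 1 hetero atom), on an amine nitrogen

Within the data shown here, no measured step covers this change. Among the measured compounds shown here, the only step known, a 1.4-fold lower number from compound 1 to compound 2 (0.14 log units; within the scatter), exchanges one terminal group for another of similar size and shows no movement beyond the scatter; it says nothing about what happens when the whole group on the amine nitrogen is taken away and only a hydrogen remains. The series therefore gives no direct guide. For compound 3 the number in this assay is expected to come out somewhat higher than for compound 1, a step of a 1.9-fold higher number from compound 1 to compound 3 (0.29 log units; within the scatter), with wide uncertainty. The estimate for compound 3 is 22000 nM, in a range from 8000 nM to 60000 nM.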

Compound 3, half-maximal inhibitory concentration: 12900 nM
Compound 3: the middle estimate sits 1.7-fold (0.23 log units) above what was measured, within the range that was stated.
By their numbers in this assay, from the lowest: compounds 2, 1 and 3 (each within the scatter of the next).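

In this assay, taking the whole group off the amine nitrogen and leaving a hydrogen atom gives a 1.1-fold higher number from compound 1 to compound 3 (0.05 log units; within the scatter), and the same replacement of (4-methylphenyl)carbamoyl gives a 1.5-fold higher number from compound 2 to compound 3 (0.19 log units; within the scatter). The earlier step only exchanged one terminal group for another, whereas these two steps compare each substituted compound with the compound carrying hydrogen at this place, and neither moves beyond the scatter, so on these three compounds neither group is shown to change the antiproliferative read-out. Nothing measured here bears on why the three numbers stay so close.

From the compounds shown here alone, whether any group on this amine nitrogen can move the number beyond the scatter remains open, for example a longer alkyl chain ending in a carboxylic acid or in a primary amine. Going by these compounds, what a fluorine or methoxy group on the shared core would do is also open, since all three compounds keep that core unchanged and so offer no reading of it.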